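Swapping the pyridyl of compound 1 for an isopropylphenyl

A few compounds are considered here, and "the series" means these few. Any claim that something is new, unique, unknown or untested is made for them only; others in the source may bear on it.

Compound 1 `O=C(NO)c1ccc(NCc2nc(-c3ccccn3)nn2-c2ccccc2)cc1` stands highest of the three numbers in an assay on Sf9 cells for inhibition of protein deacetylase HDAC6 (Homo sapiens), read by fluorescence, with a stated time of 40 min, tested at 100 nM (a higher number here means more inhibition at the concentration tested (going by the name of the read-out), a lower number less inhibition), giving 58.6%. Compound 2 `O=C(NO)c1ccc(NCc2nc(-c3ccccc3)nn2-c2ccc(C(F)(F)F)cc2)cc1` gives 38.9% in this assay, and compound 3 `NC(=O)c1ccc(NCc2nc(-c3ccccc3)nn2-c2ccccc2)cc1` gives -4.4%. Within the data shown here, both lie beyond the scatter below compound 1; no single-change step links any pair of them.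

Compound 4 `CC(C)c1ccc(-c2nc(CNc3ccc(C(=O)NO)cc3)n(-c3ccccc3)n2)cc1` is not yet measured. It differs from compound 1 by 4-isopropylphenyl in place of pyridin-2-yl on an aromatic carbon. Among the measured compounds shown here, with no measured step for this change, only an expectation can be given. The step from compound 1 to compound 4 is expected to be a moderate loss, a number 13.6 percentage points lower from compound 1 to compound 4 (beyond the scatter), since both other measured compounds sit below compound 1. In this assay compound 4 is estimated at 45%, within a range of 20% to 70%.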

Compound 4, a percentage reported as inhibition, at one concentration (the size of the read-out at that concentration, not a potency): 27.6%
Compound 4: the middle estimate sits 17.4 percentage points above what was measured; low and high end bracket the measured number.
By their numbers in this assay, from the lowest: compound 3; then compound 4; then compound 2; then compound 1.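

In this assay, the aromatic carbon of the five-membered aromatic ring with 3 nitrogen is now the first position where a single change can be read: 4-isopropylphenyl in place of pyridin-2-yl gives a number 31 percentage points lower from compound 1 to compound 4 (beyond the scatter). This position therefore does not take this exchange without a large loss, yet this one step cannot separate losing the ring nitrogen from adding the isopropyl. Nothing available explains the drop.

The compounds shown leave open whether pyridin-3-yl would hold the level of compound 1. They also leave open how a phenyl bearing an amine or a methoxy group would compare here.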